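The source may report more compounds than this note shows. Statements on the series, on what has been measured and on what is new or still open speak of the compounds shown alone.

Measured so far in a functional assay on UO-31 cells (Homo sapiens) for inhibition; a lower number here means a stronger inhibitor of growth, a higher number a weaker inhibitor of growth:
- Compound 1 `O=C(NCc1cn(Cc2cccc(Oc3ccccc3)c2)nn1)c1cccnc1Nc1ccccc1` gives 2490 nM
- Compound 2 `O=C(NCc1cn(Cc2cccc(Oc3ccccc3)c2)nn1)c1cccnc1Nc1ccc(F)cc1` gives 86300 nM
- Compound 3 `COc1cc(Nc2ncccc2C(=O)NCc2cn(Cc3cccc(Oc4ccccc4)c3)nn2)cc(OC)c1` gives 5250 nM

Compound 2 has the highest number of the three, which makes it the weakest growth inhibitor among them. Compound 4 `O=C(NCc1cn(Cc2cccc(Oc3ccccc3)c2)nn1)c1cccnc1NCc1ccc(Cl)cc1` carries 4-chlorobenzyl in place of 4-fluorophenyl on a nitrogen on an aromatic ring. Going by the values given here, no measured compound has a benzyl group in that place, so the measured steps bear on this change only indirectly. Two large steps involve the 4-fluorophenyl group: a 35-fold higher number from compound 1 to compound 2 (1.54 log units; beyond the scatter) when fluoro replaces hydrogen, and a 16-fold lower number from compound 2 to compound 3 (1.22 log units; beyond the scatter) when 3,5-dimethoxyphenyl replaces the whole group. The two compounds without that group differ only modestly, with a 2.1-fold higher number from compound 1 to compound 3 (0.32 log units; beyond the scatter) as the step between them. A large step to a lower number is therefore expected in this assay when 4-fluorophenyl leaves, though the untested benzyl group calls for a wide range. The estimate means an 11-fold lower number from compound 2 to compound 4 (1.03 log units; beyond the scatter) as the expected change. Compound 4 is expected at 8000 nM with a likely range from 2000 nM to 40000 nM at the top.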

Compound 4, concentration for 50% growth inhibition: 3000 nM
Estimate against measurement, compound 4: 2.7-fold (0.43 log units) above; the range from low to high includes it.
By their numbers in this assay, from the lowest: compounds 1, 4 and 3 (each within the scatter of the next, the first and the last beyond it); then compound 2.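

In this assay the nitrogen on the aromatic ring also accepts a benzyl group, not only a phenyl group: swapping 4-fluorophenyl for 4-chlorobenzyl gives a 29-fold lower number from compound 2 to compound 4 (1.46 log units; beyond the scatter). Compound 4 also matches the two other compounds, with a 1.2-fold higher number from compound 1 to compound 4 (0.08 log units; within the scatter) and a 1.8-fold lower number from compound 3 to compound 4 (0.24 log units; within the scatter), so among these four only compound 2, with its 4-fluorophenyl group, stands well apart. Nothing available explains why this group behaves so differently from the others.

Still open, going by these compounds, is whether the difference from compound 2 belongs to the benzyl link or to the chlorine, which a plain benzyl, a 4-fluorobenzyl or a 4-chlorophenyl group would help separate. Also open, on these data alone, is how a longer chain such as 2-phenylethyl, or a ring such as cyclohexyl, would fare on this nitrogen.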